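Compound 3: carboxy in place of cyano

The compounds below may be only part of what the source reports. "The series", "measured", "known", "first", "only" and "open" are said of these compounds alone.

Measured in a functional assay (strain AB) with Danio rerio as the target, read by microscopy, with a stated time of 1 h; on this read-out lower numbers stand for an effect already at smaller amounts and higher numbers for an effect only at larger amounts of compound
Compound 1 `CC(C)(C)CN1CCc2c(sc(NC(=O)Nc3ccc(Cl)cc3)c2C(N)=O)C1` gives 5560 nM
Compound 2 `CCN1CCc2c(sc(NC(=O)Nc3ccc(Cl)cc3)c2C#N)C1` gives > 25000 nM

For compound 2 the reading (> 25000 nM) is a limit of this assay and not a number. Compound 3 `CCN1CCc2c(sc(NC(=O)Nc3ccc(Cl)cc3)c2C(=O)O)C1` has carboxy in place of cyano on an aromatic carbon and otherwise matches compound 2. For the measured compounds named here, no measured step covers this change, so the expectation rests on the reading of compound 2 (> 25000 nM) alone: no step beyond the scatter in either direction, and quite possibly another limit. The expected step (a number no higher from compound 2 to compound 3 (the limit leaves the size open)) is small. Compound 3 is estimated at 25000 nM (expected range 10000 nM to 60000 nM).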

Compound 3, half-maximal effective concentration: > 25000 nM
Compound 3 ended at the assay's limit; the forecaster's own chance of this, stated with the estimate: 70%; the middle value lies on the limit itself.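

No step can be read between compound 2 and compound 3 in this assay, because both readings are limits of the assay and not numbers: the limit of > 25000 nM in this assay, at which 2 of the 3 values shown sit.

The compounds shown leave open whether carboxy in place of cyano on an aromatic carbon makes any difference in this assay.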